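From propoxy to methoxy on a shared core

This account rests on a few compounds, and the source may have more. Where it says the series, first, only, none or still open, it means among the compounds named here.

Of the compounds shown here, three with a shared core have been tested in a functional assay on KB 3-1 cells (Homo sapiens) for inhibition, with a stated time of 72 h (a higher number here means a weaker inhibitor, a lower number a stronger inhibitor), so far. Compound 1 `CC(=O)Oc1c(OCc2ccccc2)cc2oc(-c3ccccc3)cc(=O)c2c1OC(C)=O` gives 13700 nM in this assay and is the only one of the three with a number. Compound 2 `CCCOc1c(O)cc2oc(-c3ccccc3)cc(=O)c2c1O` gives > 100000 nM and this is a limit of the assay, not a number. Compound 3 `CCCOc1cc2oc(-c3ccccc3)cc(=O)c2c(O)c1OCCC` gives > 100000 nM and this too is a limit, not a number. The standing of compound 3 is therefore given by the limit of > 100000 nM in this assay, at which 2 of the 3 values shown sit, and not by a measured number.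

The next structure is compound 4 `CCCOc1c(OC)cc2oc(-c3ccccc3)cc(=O)c2c1O` and the change that leads to it is hydrogen in place of ethyl on a saturated chain carbon bound to an oxygen on an aromatic ring (one propoxy becomes methoxy, with the rest of compound 3 kept). Among the measured compounds shown here, the only measured step that bears on this change is a step that the two limits leave unreadable from compound 2 to compound 3 and it offers no size to carry over. For the measured compounds named here, no step of a known size or direction can therefore be expected in this assay from the data so far. The step expected is an at least 1.1-fold lower number from compound 3 to compound 4 (0.04 log units; that floor lies within the scatter) and it remains a rough estimate. For compound 4 the estimated value is 90000 nM with an expected range from 30000 nM to 200000 nM and a report of only a limit is the likeliest outcome.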

Compound 4, half-maximal inhibitory concentration: > 100000 nM
Compound 4 ended at the assay's limit; the forecaster's own chance of this, stated with the estimate: 75%; middle value at least 1.1-fold (0.04 log units) away from the limit.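

Compound 2, compound 3 and compound 4 all give only a limit, not a number, in this assay, so no step among them can be read: the limit of > 100000 nM in this assay, at which 3 of the 4 values shown sit.

The compounds shown leave open whether the change from propoxy to methoxy alters the half-maximal inhibitory concentration on the shared core at all, in either direction.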